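Capping the Phenol: From Compound 1 to Compound 3

The compounds below may be only part of what the source reports. "The series", "measured", "known", "first", "only" and "open" are said of these compounds alone.

Compound 1 `O=C(Nc1cccc(-n2cc(-c3ccncc3)c(-c3cc(O)cc(Cl)c3)n2)c1)Nc1ccc(Cl)c(C(F)(F)F)c1` gives 96%
Compound 2 `O=C(Nc1cccc(-n2cc(-c3ccncc3)c(-c3cc(O)cc(Cl)c3)n2)c1)Nc1ccc(Cl)c(Cl)c1` gives 109%

Both compounds were tested in a functional assay on NCI/ADR-RES cells (Homo sapiens) for inhibition, read by sulforhodamine B assay, with a stated time of 48 h, tested at 0.01 uM; on this read-out lower numbers stand for a stronger effect and higher numbers for a weaker effect at the one concentration tested. Going by the values given here, compound 1 has the lower of the two numbers, and the only measured step, a number 13 percentage points higher from compound 1 to compound 2 (beyond the scatter), is a modest one that moves beyond the scatter but leaves both compounds close to no effect at this concentration.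

Compound 3 `COc1cc(Cl)cc(-c2nn(-c3cccc(NC(=O)Nc4ccc(Cl)c(C(F)(F)F)c4)c3)cc2-c2ccncc2)c1` has not been measured. It differs from compound 1 by methyl in place of hydrogen on an oxygen on an aromatic ring, so hydroxy becomes methoxy on the shared core. Among the compounds with values here, the one measured step concerns a different group at a different place, so no measured step bears on this change, and nothing in the two values suggests that a small change of this kind moves the read-out far.

The step is therefore expected to be a number 2 percentage points higher from compound 1 to compound 3 (within the scatter), that is, none beyond the scatter. Compound 3 is estimated at 98%, with a range from 84% to 112%.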

Compound 3, a percentage reported as activity, at one concentration (the size of the read-out at that concentration, not a potency): 98%
Compound 3: middle estimate and measured number agree at the digits printed, within the range that was stated.
By their numbers in this assay, from the lowest: compounds 1 and 3 (each within the scatter of the next); then compound 2.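

In this assay, methyl in place of hydrogen on this oxygen gives a number 2 percentage points higher from compound 1 to compound 3 (within the scatter), so at this one concentration the read-out does not separate hydroxy from methoxy on the shared core. Going by these compounds alone, this is the only view of this position so far, and because compound 1 already stood close to no effect, the flat result cannot say whether the hydrogen of the hydroxy matters at concentrations where a clear effect appears. Nothing measured here offers an explanation for the result.

Still open, on these data alone, is whether a longer chain on this oxygen, such as ethoxy, or an amine in place of the hydroxy would move the number. Also open, as far as these compounds go, is whether methoxy would read the same with chloro in place of trifluoromethyl, the other change seen.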